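Cytotoxicity of side-chain amides, from compound 3 to compound 4

This account rests on a few compounds, and the source may have more. Where it says the series, first, only, none or still open, it means among the compounds named here.

Values measured in a functional assay on HepG2 cells (Homo sapiens) for cytotoxicity, read by MTT assay, with a stated time of 72 h; a higher number here means a weaker inhibitor, a lower number a stronger inhibitor
- compound 1 `Cn1cccc1-c1nc2cc(NC(=O)CCCl)ccc2[nH]1` gives > 50000 nM (a limit)
- compound 2 `Cc1ccc(-c2nc3cc(NC(=O)CN4CCN(C)CC4)ccc3[nH]2)cc1` gives > 50000 nM (a limit)
- compound 3 `CCN1CCN(CC(=O)Nc2ccc3[nH]c(-c4ccc(C)cc4)nc3c2)CC1` gives 31900 nM

Going by the values given here, compound 3 is the only compound with a number. Compound 1 and compound 2 share the limit of > 50000 nM in this assay, at which 2 of the 3 values shown sit, and have no number.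

Compound 4 `Cc1ccc(-c2nc3cc(NC(=O)CCCl)ccc3[nH]2)cc1` departs from compound 3 by chloromethyl in place of 4-ethylpiperazin-1-yl on a saturated chain carbon bound to a carbonyl carbon and keeps the rest of the structure. Among the compounds with values here, the one measured step on this side chain is an at least 1.5-fold lower number from compound 2 to compound 3 (0.19 log units; that floor lies within the scatter) and, at its floor, gives little guide to size. Compound 1 also carries the 2-chloroethyl group and gives > 50000 nM, which is a limit. No measurement covers the exchange itself, so no step beyond the scatter is expected in this assay, and a limit is as likely as a number. The estimated move is a 1.1-fold higher number from compound 3 to compound 4 (0.04 log units; within the scatter) and stays within that expectation. The estimate for compound 4 is 35000 nM (expected range 12000 nM to 70000 nM).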

Compound 4, half-maximal inhibitory concentration: > 50000 nM
Compound 4: no number, only a limit; the forecaster's own chance of this, stated with the estimate: 50%; middle value at least 1.4-fold (0.15 log units) away from the limit.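

In this assay, chloromethyl in place of 4-ethylpiperazin-1-yl on the saturated chain carbon bound to a carbonyl carbon gives an at least 1.5-fold higher number from compound 3 to compound 4 (0.19 log units; that floor lies within the scatter), so even this large change of side chain has no readable size beyond the scatter. The 2-chloroethyl side chain now gives a limit with both the 4-methylphenyl and the 1-methyl-1H-pyrrol-2-yl group, and the steps from compound 1 and from compound 2 to compound 4 join two limits and cannot be read. Compound 3 remains the only compound with a number: the limit of > 50000 nM in this assay, at which 3 of the 4 values shown sit.

From the compounds shown here alone, how far the true value of compound 4 lies from compound 3 stays open. Also open, going by these compounds, is whether a morpholin-4-yl or dimethylamino group on the same chain carbon would give a number.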